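The source may report more compounds than this note shows. Statements on the series, on what has been measured and on what is new or still open speak of the compounds shown alone.

Two compounds that share one core, and a third built on a different core, have been tested in a functional assay on HT-29 cells (Homo sapiens) for inhibition, read by sulforhodamine B assay, with a stated time of 72 h; on this read-out lower numbers stand for stronger inhibition and higher numbers for weaker inhibition. Compound 1 `COc1cc2c(Nc3ccc(OCc4cccc(F)c4)c(Cl)c3)ncnc2cc1OCCCCCn1ccnc1[N+](=O)[O-]` carries a chain of five saturated carbons between an oxygen on an aromatic ring and a 2-nitro-1H-imidazol-1-yl group, and in this assay compound 1 gives 5040 nM. Compound 2 `COc1cc2c(Nc3ccc(OCc4cccc(F)c4)c(Cl)c3)ncnc2cc1OCCCCCCn1ccnc1[N+](=O)[O-]` lengthens that chain by one carbon. In this assay compound 2 reaches only the limit of > 50000 nM, which is a limit of the measurement and not a number. The change from compound 1 to compound 2 is (2-nitro-1H-imidazol-1-yl)methyl in place of 2-nitro-1H-imidazol-1-yl on a saturated chain carbon, five bonds along the chain from an oxygen on an aromatic ring, and it produced an at least 9.9-fold higher number from compound 1 to compound 2 (0.99 log units; beyond the scatter), a step that rests on (the limit of > 50000 nM in this assay, at which 1 of the 3 values shown sits).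

Compound 3 `COc1cc2c(Nc3cccc(Br)c3)ncnc2cc1OCCCCCn1ccnc1[N+](=O)[O-]` has the same chain and the same 2-nitro-1H-imidazol-1-yl group as compound 1 but a different core; the difference between the two cores is not broken down here. In this assay compound 3 gives 2540 nM, and the values of compound 1 and compound 3 lie within the scatter of each other.

Compound 4 `COc1cc2c(Nc3cccc(Br)c3)ncnc2cc1OCCCCCCn1ccnc1[N+](=O)[O-]` has not yet been measured. It differs from compound 3 by (2-nitro-1H-imidazol-1-yl)methyl in place of 2-nitro-1H-imidazol-1-yl on a saturated chain carbon, five bonds along the chain from an oxygen on an aromatic ring, the same change that separates compound 1 from compound 2, at the same place. Because the earlier step gave an at least 9.9-fold higher number from compound 1 to compound 2 (0.99 log units; beyond the scatter), the expectation is that compound 4 will also give a clearly higher number. The expected step is a 9.8-fold higher number from compound 3 to compound 4 (0.99 log units; beyond the scatter), an estimate rather than a measurement. Compound 4 is estimated at 25000 nM, expected to lie between 7000 nM and 50000 nM, with a real chance that the assay again reports only a limit.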

Compound 4, half-maximal inhibitory concentration: 4300 nM
Compound 4: middle estimate off by 5.8-fold (0.76 log units), on the high side, outside the stated range (below it).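

In this assay the one-carbon extension, (2-nitro-1H-imidazol-1-yl)methyl in place of 2-nitro-1H-imidazol-1-yl, gives a 1.7-fold higher number from compound 3 to compound 4 (0.23 log units; within the scatter), so the large step seen on the first core did not carry over in size to the second, and the two steps differ: the same change on two cores in this assay, an at least 9.9-fold higher number (0.99 log units; beyond the scatter) from compound 1 to compound 2 and a 1.7-fold higher number (0.23 log units; within the scatter) from compound 3 to compound 4, at least 5.8-fold (0.76 log units) apart, beyond the scatter of two such steps. Compound 2 stands only at a limit of the measurement and not at a number, so the step on the first core has a known lower bound but no known full size: the limit of > 50000 nM in this assay, at which 1 of the 4 values shown sits. The result shows that, for these two pairs, the outcome of lengthening the chain depends on the core it is attached to, but with a single pair on each core it does not show which part of the core matters or why, and it gives no rule for any other core.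

The compounds shown leave open how a still longer chain, or a shorter one, would behave on each of the two cores, and whether the contrast would hold if an amine replaced the 2-nitro-1H-imidazol-1-yl group. They also leave open which of the two patterns a third core would follow, the large step or the one within the scatter.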